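Lengthening the amine chain of compound 2

The compounds below may be only part of what the source reports. "The series", "measured", "known", "first", "only" and "open" are said of these compounds alone.

Measured in an ADME assay on MT4 cells (Homo sapiens) for cytotoxicity, read by MTT assay, with a stated time of 4 days; on this read-out higher numbers stand for lower toxicity in this test and lower numbers for higher toxicity in this test:
- compound 1 `Cc1c(Cc2c(F)cccc2F)nc(N(C)C)[nH]c1=O`, > 89000 nM (a limit)
- compound 2 `Cc1c(C(C)c2c(F)cccc2F)nc(N(C)C)[nH]c1=O`, > 17000 nM (a limit)
- compound 3 `Cc1c(C(C)c2ccccc2F)nc(N(C)C)[nH]c1=O`, 44000 nM

Compound 2 stands only at a limit, > 17000 nM. Compound 4 `CCCN(C)c1nc(C(C)c2c(F)cccc2F)c(C)c(=O)[nH]1` carries methyl(propyl)amino where compound 2 carries dimethylamino, a change counted as ethyl in place of hydrogen on a saturated chain carbon bound to a nitrogen on an aromatic ring.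

Neither measured step touches this place, and neither has a readable size. They are a step that the two limits leave unreadable from compound 1 to compound 2 and a step that the limit leaves unreadable from compound 2 to compound 3. Within the data shown here, the only true number nearby belongs to compound 3, at 44000 nM, so the expectation leans on that value. No firm direction can therefore be expected in this assay, and no large step is expected either. The expected change is a step that the limit leaves unreadable from compound 2 to compound 4. The assay may again report only a limit. For compound 4 the estimated value is 30000 nM, with an expected range from 9000 nM to 100000 nM.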

Compound 4, half-maximal cytotoxic concentration: > 78000 nM
Compound 4 was reported as a limit; the forecaster's own chance of this, stated with the estimate: 45%; middle value at least 2.6-fold (0.41 log units) from the limit.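

Among these compounds, compound 2 and compound 4 are both reported only as limits, so no step between them can be read. The compounds shown leave open whether methyl(propyl)amino in place of dimethylamino changes the read-out in this assay at all, and in which direction.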